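Shifting the naphthalene attachment point in compound 1

The source may report more compounds than this note shows. Statements on the series, on what has been measured and on what is new or still open speak of the compounds shown alone.

Compound 1 `COC(C(=O)OC(C)Cn1cnc2c1c(=O)n(C)c(=O)n2C)c1cccc2ccccc12` was tested in a functional assay on MCF7 cells (Homo sapiens) for antiproliferative activity, read by MTT assay, with a stated time of 72 h, tested at 50 uM (a higher number here means a weaker effect of the compound at the concentration tested, a lower number a stronger effect), where compound 1 gives 87.7%. Its only measured companion, compound 2 `CC(Cn1cnc2c1c(=O)n(C)c(=O)n2C)OC(=O)CC(=O)c1ccc(F)cc1`, in this assay gives 77.9%; these two numbers lie within the usual scatter of each other, so neither compound can be called the stronger. Compound 3 `COC(C(=O)OC(C)Cn1cnc2c1c(=O)n(C)c(=O)n2C)c1ccc2ccccc2c1` has not yet been measured. It differs from compound 1 by naphthalen-2-yl in place of naphthalen-1-yl on a saturated chain carbon bound to a carbonyl carbon and an oxygen on a saturated carbon. Going by the values given here, no measured pair shows this kind of change, so the step of a number 2.7 percentage points lower from compound 1 to compound 3 (within the scatter) is expected to be none beyond the scatter. Compound 3 is therefore estimated to give about 85% in this assay, with a range from 70% to 98%.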

Compound 3, a percentage reported as activity, at one concentration (the size of the read-out at that concentration, not a potency): 86.3%
Compound 3: the middle estimate sits 1.3 percentage points below what was measured; low and high end bracket the measured number.
By their numbers in this assay, from the lowest: compounds 2, 3 and 1 (each within the scatter of the next).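

In this assay the change from naphthalen-1-yl to naphthalen-2-yl on this saturated chain carbon gives a number 1.4 percentage points lower from compound 1 to compound 3 (within the scatter) and thus provides the first step read at this position. The two attachment points of the naphthalene therefore cannot be told apart in this read-out. No available evidence bears on this result. From the compounds shown here alone, whether an amine or a pyridine ring in place of the naphthalene would move the number beyond the scatter remains open.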